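The compounds below may be only part of what the source reports. "The series", "measured", "known", "first", "only" and "open" are said of these compounds alone.

Measured so far:
- Compound 1, `CCCCCCNC(=O)CCC(NS(=O)(=O)c1cc(Cl)ccc1Cl)C(=O)NCCCCCC`: 12.4%
- Compound 2, `O=C(CCC(NS(=O)(=O)c1cc(Cl)ccc1Cl)C(=O)Nc1ccccc1)Nc1ccccc1`: 22.9%

In a functional assay on IMR-32 cells (Homo sapiens) for cytotoxicity, read by MTT assay, tested at 60 ug/mL (a lower number here means less inhibition, a higher number more inhibition at the concentration tested (going by the name of the read-out)), compound 2 gives 22.9%, the higher of the two numbers; compound 1 sits lower by more than the usual scatter of repeated measurements.

Compound 3, `O=C(CCC(NS(=O)(=O)c1ccc(Br)cc1)C(=O)Nc1ccccc1)Nc1ccccc1`, differs from compound 2 in one place: 4-bromophenyl in place of 2,5-dichlorophenyl on a sulfonyl sulfur. Going by the values given here, no measured pair shows what this exchange of one halogenated ring for another does here, so the two values of compounds 1 and 2 give no direct guide. The step of a number 2.9 percentage points lower from compound 2 to compound 3 (within the scatter) is expected to be small, not beyond the scatter in either direction. Compound 3 is therefore estimated at 20%, with a range from 8% to 34%.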

Compound 3, a percentage reported as inhibition, at one concentration (the size of the read-out at that concentration, not a potency): 10%
For compound 3 the middle estimate is 10 percentage points above the measured one, within the range that was stated.
By their numbers in this assay, from the lowest: compounds 3 and 1 (each within the scatter of the next); then compound 2.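

In this assay, putting 4-bromophenyl in place of 2,5-dichlorophenyl on a sulfonyl sulfur gives a number 12.9 percentage points lower from compound 2 to compound 3 (beyond the scatter), so the ring on this sulfur does affect the read-out. Compound 1 and compound 2 carry the same ring there and could not show this. No available evidence explains the step. The exchange changes the halogens and their places on the ring together, and the compounds shown do not separate these two changes. As far as these compounds go, how a plain phenyl or a methoxyphenyl on this sulfur would read also remains open.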